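Bromo to nitro exchange on the shared core

The compounds below may be only part of what the source reports. "The series", "measured", "known", "first", "only" and "open" are said of these compounds alone.

Compound 1 `COc1ccc(C(=O)/C=C/c2ccc(Br)cc2)c2c1C=CC(C)(C)O2` is one of two members of the series measured in a functional assay on HepG2 cells (Homo sapiens) for antiproliferative activity, read by MTT assay, with a stated time of 24 h; a lower number here means a stronger inhibitor, a higher number a weaker inhibitor. For compound 1 the result is only a limit, > 10000 nM, so its standing on the numbers can be given no closer than that. Compound 2 `COc1ccc(C(=O)/C=C/c2ccc3ccccc3n2)c2c1C=CC(C)(C)O2`, which carries a different aromatic system at the same end of the molecule, gives 4280 nM in this assay. Within the data shown here, because compound 1 sits at the limit of > 10000 nM in this assay, at which 1 of the 2 values shown sits, the two values show only that compound 2 reaches a number where compound 1 does not.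

Compound 3 `COc1ccc(C(=O)/C=C/c2ccc([N+](=O)[O-])cc2)c2c1C=CC(C)(C)O2` has not yet been measured. It differs from compound 1 by nitro in place of bromo on an aromatic carbon. Among the measured compounds shown here, no measured pair makes this change, so its size is not known from the data. In this assay a step from compound 1 to compound 3 of an at least 1.2-fold lower number from compound 1 to compound 3 (0.09 log units; that floor lies within the scatter) is expected, with no basis for a direction beyond the scatter. Compound 3 is therefore estimated at 8000 nM, between 2500 nM and 30000 nM.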

Compound 3, half-maximal inhibitory concentration: 2610 nM
For compound 3 the middle estimate is 3.1-fold (0.49 log units) above the measured one, within the range that was stated.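

Nitro in place of bromo on an aromatic carbon, para to a large group, gives an at least 3.8-fold lower number from compound 1 to compound 3 (0.58 log units; beyond the scatter) in this assay, so this change now has a measured direction that no earlier pair supplied. With the shared core unchanged, this end of the molecule is shown to respond to the exchange of a single group, 4-bromophenyl to 4-nitrophenyl. The step is a floor and not an exact size, as the value for compound 1 is a limit: the limit of > 10000 nM in this assay, at which 1 of the 3 values shown sits.

The compounds shown carry only bromo and nitro at this position within the 4-substituted phenyl pair, so the outcome with an amine or a carboxylic acid there remains open, and with it whether the step belongs to nitro alone or would be shared by other groups. Also open, on these data alone, is the true distance between compound 1 and compound 3, and whether the same exchange would give a step of similar direction on a core other than the shared one.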